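Replacing methylsulfonyl with (isopropylcarbonyl)amino on compound 3

A few compounds are considered here, and "the series" means these few. Any claim that something is new, unique, unknown or untested is made for them only; others in the source may bear on it.

Measured in an assay on isolated protein for inhibition of Ephrin type-A receptor 2 (Homo sapiens), read by thermal shift assay, tested at 10 uM; on this read-out higher numbers stand for stronger stabilisation of the target against heat and lower numbers for weaker stabilisation of the target:
compound 1 `CC(C)(C)c1cc(NC(=O)Nc2ccc(F)cc2)n(-c2ccccc2)n1` gives -2.2 degrees C
compound 2 `CC(C)(C)c1cc(NC(=O)Nc2ccc(Cl)cc2)n(-c2ccc(OC(F)(F)F)cc2)n1` gives 0.9 degrees C
compound 3 `CC(C)(C)c1cc(NC(=O)Nc2ccc(Cl)cc2)n(-c2ccc(S(C)(=O)=O)cc2)n1` gives 1.2 degrees C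

Compound 3 holds the highest of these three numbers in this assay, though the step of a number 0.30 degrees C higher from compound 2 to compound 3 (within the scatter) is within the scatter, so compound 2 and compound 3 cannot be ordered. Compound 1 stands apart, beyond the scatter.

Compound 4 `CC(C)C(=O)Nc1ccc(-n2nc(C(C)(C)C)cc2NC(=O)Nc2ccc(Cl)cc2)cc1` differs from compound 3 in one place: (isopropylcarbonyl)amino in place of methylsulfonyl on an aromatic carbon. Among the measured compounds shown here, the only measured step at that place is a number 0.30 degrees C higher from compound 2 to compound 3 (within the scatter), a swap of one group for another at the same aromatic carbon that left the number essentially unchanged. No larger guide exists. The expected step of no change at the digits printed from compound 3 to compound 4 (within the scatter) is therefore none beyond the scatter. Compound 4 is estimated at 1.2 degrees C, in a range from -1.2 degrees C to 3.6 degrees C.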

Compound 4, shift of the target's melting temperature: 2.8 degrees C
Estimate against measurement, compound 4: 1.6 degrees C below; the measured number falls inside the stated range.
By their numbers in this assay, from the lowest: compound 1; then compounds 2 and 3 (each within the scatter of the next); then compound 4.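

In this assay, the aromatic carbon para to a large group now proves able to move the number beyond the scatter, with (isopropylcarbonyl)amino replacing methylsulfonyl (a number 1.6 degrees C higher from compound 3 to compound 4 (beyond the scatter)) and trifluoromethoxy (a number 1.9 degrees C higher from compound 2 to compound 4 (beyond the scatter)). The earlier swap between methylsulfonyl and trifluoromethoxy had shown no readable change, so this place does respond to the group it carries. Nothing at hand explains the rise.

The compounds shown leave open how an amine or a carboxylic acid at this carbon would read, and whether a longer chain on the carbonyl would raise the number further.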